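The source may report more compounds than this note shows. Statements on the series, on what has been measured and on what is new or still open speak of the compounds shown alone.

Measured compounds:
Compound 1 `N#C[Se]c1ccc(NC(=O)OCc2ccc([N+](=O)[O-])cc2)cc1` — in a functional assay on CCRF-CEM cells (Homo sapiens) for cytotoxicity, read by MTT assay, with a stated time of 72 h (a lower number here means a stronger inhibitor of growth, a higher number a weaker inhibitor of growth), compound 1 gives 38300 nM.
Compound 2 `C=CCOC(=O)Nc1ccc([Se]C#N)cc1` — in this assay compound 2 gives 38100 nM.

Two compounds share a core and differ only in the group on the carbamate oxygen. The number for compound 2 and the number for compound 1 lie within the scatter of each other, so the two cannot be told apart in this assay, even though the groups on the oxygen differ considerably.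

Compound 3 `CC(C)COC(=O)Nc1ccc([Se]C#N)cc1` is not yet measured. It differs from compound 2 in one place: isopropyl in place of vinyl on a saturated chain carbon bound to an oxygen next to a carbonyl group. Since the much larger change from compound 2 to compound 1 left the number where it was, no step beyond the scatter is expected for a 1.0-fold lower number from compound 2 to compound 3 (0.00 log units; within the scatter). Compound 3 is therefore expected to give about 38000 nM, with a range from 19000 nM to 76000 nM.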

Compound 3, concentration for total growth inhibition: 38300 nM
The estimate for compound 3 lay 1.0-fold (0.00 log units) below the measured number, within the range that was stated.
By their numbers in this assay, from the lowest: compounds 2, 1 and 3 (each within the scatter of the next).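

Replacing allyl with isobutyl on the carbamate oxygen gives a 1.0-fold higher number from compound 2 to compound 3 (0.00 log units; within the scatter) in this assay, so compound 2 and compound 3 cannot be told apart there. The earlier pair showed that this position tolerates a large difference in the group on the oxygen; this step adds that the double bond outside aromatic rings in compound 2 can be absent from compound 3, with isopropyl in place of vinyl, and the numbers still lie within the scatter. Nothing available explains why these numbers lie so close together.

The compounds shown leave open whether an amine or a carboxylic acid on this chain, or a much longer chain, would move the number beyond the scatter. They also leave open what happens when the carbamate oxygen itself is replaced by a nitrogen or a methylene group.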